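Lengthening the chain between sulfonamide and amine

The compounds below may be only part of what the source reports. "The series", "measured", "known", "first", "only" and "open" are said of these compounds alone.

Of the compounds shown here, three have been measured in a functional assay on MIA PaCa-2 cells (Homo sapiens) for inhibition, read by MTT assay, with a stated time of 72 h; a higher number here means a weaker inhibitor of growth, a lower number a stronger inhibitor of growth. Compound 1 `O=S(=O)(NCCCNCc1ccccc1Cl)c1cc(C(F)(F)F)cc(C(F)(F)F)c1` gives 11000 nM, compound 2 `O=S(=O)(NCCCCNCc1ccc(Br)cc1)c1cc(C(F)(F)F)cc(C(F)(F)F)c1` gives 2100 nM, and compound 3 `CN(CCCNS(=O)(=O)c1cc(C(F)(F)F)cc(C(F)(F)F)c1)Cc1ccccc1` gives 33000 nM. Compound 2 stands lowest of the three: the step of a 5.2-fold lower number from compound 1 to compound 2 (0.72 log units; beyond the scatter), and the step of a 16-fold higher number from compound 2 to compound 3 (1.20 log units; beyond the scatter), both beyond the scatter. Compound 4 `O=S(=O)(NCCCCCCNCc1ccc(Br)cc1)c1cc(C(F)(F)F)cc(C(F)(F)F)c1` differs from compound 2 by 2-((4-bromobenzyl)amino)ethyl in place of (4-bromobenzyl)amino on a saturated chain carbon, four bonds along the chain from a sulfonamide nitrogen, so only the saturated chain grows longer while both ends stay the same. Among the measured compounds shown here, no measured step changes the chain alone. The step of a 5.2-fold lower number from compound 1 to compound 2 (0.72 log units; beyond the scatter) combines a longer chain with a different halogen on the benzyl ring, and the step of a 16-fold higher number from compound 2 to compound 3 (1.20 log units; beyond the scatter) changes the amine and removes the halogen, so neither isolates the effect of chain length. A modest step in either direction, or none beyond the scatter, is therefore plausible, and the expected step is a 1.3-fold lower number from compound 2 to compound 4 (0.12 log units; within the scatter). Compound 4 is estimated at 1600 nM in this assay, with a likely range from 500 nM to 5000 nM.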

Compound 4, concentration for 50% growth inhibition: 2970 nM
The estimate for compound 4 lay 1.9-fold (0.27 log units) below the measured number; the measured number falls inside the stated range.
By their numbers in this assay, from the lowest: compounds 2 and 4 (each within the scatter of the next); then compound 1; then compound 3.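

Among the compounds shown here, this is the first step that changes the saturated chain alone, with the shared core and the bromobenzyl end kept the same: in this assay, placing 2-((4-bromobenzyl)amino)ethyl where (4-bromobenzyl)amino stood gives a 1.4-fold higher number from compound 2 to compound 4 (0.15 log units; within the scatter). At this position, then, the lengthening leaves the number within the usual scatter, and the two chain lengths cannot be told apart in this assay. Nothing measured here bears on the reason for this result.

The compounds shown leave open whether a still longer chain, or a shorter chain ending in the same (4-bromobenzyl)amino group, would keep the number at this level. They also leave open what a chlorine in place of the bromine would do on the longer chain.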